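Trading a Nitro Group for a Carboxymethylamino Arm

The source may report more compounds than this note shows. Statements on the series, on what has been measured and on what is new or still open speak of the compounds shown alone.

Compound 1 `Oc1ccc(CNc2cc(C(F)(F)F)cc3[nH]ncc23)c(Cl)c1`: 97%
Compound 2 `O=[N+]([O-])c1cccc(CNc2cc(Br)cc3[nH]ncc23)c1`: 97%
Compound 3 `O=[N+]([O-])c1cccc(CNc2cc(C(F)(F)F)cc3[nH]ncc23)c1`: 82%

In an assay for inhibition of Tryptophan 2,3-dioxygenase (Homo sapiens), with stated times of 10 min and 60 min, tested at 100 uM (on this read-out lower numbers stand for a weaker effect and higher numbers for a stronger effect at the one concentration tested), compound 3 gives the lowest of the three numbers, sitting beyond the scatter under both compound 1 and compound 2. For the measured compounds named here, the only single change measured so far is a number 15 percentage points lower from compound 2 to compound 3 (beyond the scatter), a swap on the shared core rather than on the outer ring. Compound 4 `O=C(O)CNc1cccc(CNc2cc(C(F)(F)F)cc3[nH]ncc23)c1` differs from compound 3 by (carboxymethyl)amino in place of nitro on an aromatic carbon. Going by the values given here, no measured step touches that outer ring, so nothing here tells how large or in which direction the step should be; the change is therefore expected to stay roughly flat, with wide uncertainty, giving a number 4 percentage points lower from compound 3 to compound 4 (within the scatter). Compound 4 is estimated at 78%, with a range from 45% to 95%.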

Compound 4, a percentage reported as inhibition, at one concentration (the size of the read-out at that concentration, not a potency): 65%
Compound 4: middle estimate off by 13 percentage points, on the high side; the range from low to high includes it.
By their numbers in this assay, from the lowest: compound 4; then compound 3; then compounds 1 and 2 (each within the scatter of the next).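

In this assay, the change of nitro to (carboxymethyl)amino gives a number 17 percentage points lower from compound 3 to compound 4 (beyond the scatter). For the compounds shown here, this is the first measured step on the outer ring, and it shows that the substituent at this position can move the read-out beyond the scatter. The larger arm still leaves compound 4 at 65%, so the position accepts it with only a modest loss. No available evidence explains the drop.

Still open, on these data alone, is which part of the arm matters. A plain amine or a longer chain ending in a carboxylic acid at the same place could help separate the effect of the nitrogen link from that of the acid end.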